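The source may hold more compounds than are shown below. What is called first, only, known or untested is meant among the compounds shown, and "the series" means these compounds.

Two compounds from this series share one core and differ only in the aromatic group attached to it. Compound 1 `Cc1cccc(-c2cn3ccnc3c(-c3ccc4ncn(Cc5ccccc5)c4c3)n2)c1` carries a 3-methylphenyl group, and compound 2 `O=Cc1ccc(-c2cn3ccnc3c(-c3ccc4ncn(Cc5ccccc5)c4c3)n2)cc1` carries a 4-formylphenyl group in its place. In a functional assay on IGROV-1 cells (Homo sapiens) for inhibition, read by sulforhodamine B assay, with a stated time of 48 h, tested at 10 uM (on this read-out lower numbers stand for less inhibition and higher numbers for more inhibition at the one concentration tested (going by the name of the read-out)), compound 1 gives 9.51%, and in this assay compound 2 gives 21.3%. Among the measured compounds shown here, the one measured step, a number 11.8 percentage points higher from compound 1 to compound 2 (beyond the scatter), is the only comparison available, and it puts compound 2 at the higher of the two numbers, with compound 1 sitting lower by that same step.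

Compound 3 `c1ccc(Cn2cnc3ccc(-c4nc(-c5cccc6ccccc56)cn5ccnc45)cc32)cc1` is the next member, not yet measured. It differs from compound 2 by the change (naphthalen-1-yl in place of 4-formylphenyl on an aromatic carbon). For the measured compounds named here, the entering naphthalen-1-yl, like the 3-methylphenyl of compound 1, has no hydrogen-bond acceptor, whereas the leaving 4-formylphenyl had one; the single step shows that swapping an acceptor-free ring for the formyl-bearing one raised the number, so the reverse direction is expected to lower it. For compound 3 in this assay the expected change is a number 9.3 percentage points lower from compound 2 to compound 3 (within the scatter), a modest drop. Compound 3 is therefore estimated at 12%, with a range from 0% to 28%.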

Compound 3, a percentage reported as inhibition, at one concentration (the size of the read-out at that concentration, not a potency): 11.3%
Beside the measured number, compound 3's estimate is 0.7 percentage points above it, within the range that was stated.
By their numbers in this assay, from the lowest: compounds 1, 3 and 2 (each within the scatter of the next, the first and the last beyond it).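

Moving from the single ring of 3-methylphenyl to naphthalen-1-yl, with its 2 six-membered aromatic rings of carbon only, gives in this assay a number 1.8 percentage points higher from compound 1 to compound 3 (within the scatter), so the two groups without a hydrogen-bond acceptor cannot be told apart at this position. Replacing 4-formylphenyl with naphthalen-1-yl gives a number 10 percentage points lower from compound 2 to compound 3 (within the scatter), so compound 3 cannot be separated from compound 2 either, and only compound 1 and compound 2 remain distinct, which keeps any split between groups with and without an acceptor from being clean. No measurement here accounts for these numbers, and the small set offers no explanation of why the groups compare as they do.

The compounds shown leave open whether the formyl group itself matters, since a plain phenyl ring, a 4-hydroxymethylphenyl group or a 4-carboxyphenyl group would each test that ring with a different group, or none, in the same place. Going by these compounds, it is also open whether an amine or a longer chain on this aromatic carbon would move the number clearly beyond that of compound 2.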